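Sulfonamide to Urea on a Shared Indole Core

The source may report more compounds than this note shows. Statements on the series, on what has been measured and on what is new or still open speak of the compounds shown alone.

Three compounds share one core and differ only in the group on a nitrogen on an aromatic ring. Compound 1 `CC(=O)N(C)c1ccc2[nH]c(-c3n[nH]c4ccccc34)cc2n1` carries an acetyl there, and in a functional assay on KB cells (Homo sapiens) for antiproliferative activity, read by MTT assay, with a stated time of 72 h (on this read-out higher numbers stand for weaker inhibition and lower numbers for stronger inhibition), compound 1 gives 10300 nM. Compound 2 `CN(C(=O)c1ccc(Cl)cc1)c1ccc2[nH]c(-c3n[nH]c4ccccc34)cc2n1` carries a (4-chlorophenyl)carbonyl, and in this assay compound 2 gives 630 nM. Compound 3 `CN(c1ccc2[nH]c(-c3n[nH]c4ccccc34)cc2n1)S(=O)(=O)c1ccccc1` carries a phenylsulfonyl, and in this assay compound 3 gives 2400 nM, the second highest of the three numbers. The measured steps are a 16-fold lower number from compound 1 to compound 2 (1.21 log units; beyond the scatter), a 4.3-fold lower number from compound 1 to compound 3 (0.63 log units; beyond the scatter) and a 3.8-fold higher number from compound 2 to compound 3 (0.58 log units; beyond the scatter). Compound 4 `CN(C(=O)Nc1ccccc1)c1ccc2[nH]c(-c3n[nH]c4ccccc34)cc2n1` is the next step: phenylcarbamoyl in place of phenylsulfonyl on a nitrogen on an aromatic ring. Among the measured compounds shown here, no measured step exchanges a sulfonyl for a carbamoyl directly, but a 3.8-fold higher number from compound 2 to compound 3 (0.58 log units; beyond the scatter) shows the carbonyl-bearing aryl group of compound 2 at a lower number than the sulfonyl of compound 3, and the phenylcarbamoyl of compound 4 likewise holds a carbonyl. A modest fall in this assay is therefore expected, about a 2.0-fold lower number from compound 3 to compound 4 (0.30 log units; within the scatter). Compound 4 is thus estimated at 1200 nM, with a range from 400 nM to 4000 nM.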

Compound 4, half-maximal inhibitory concentration: 32 nM
Compound 4: middle estimate off by 38-fold (1.57 log units), on the high side; measured number outside the range, below it.
By their numbers in this assay, from the lowest: compound 4; then compound 2; then compound 3; then compound 1.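

On this nitrogen on an aromatic ring, phenylcarbamoyl gives the lowest number of the four in this assay, and its exchange for phenylsulfonyl brings a 75-fold lower number from compound 3 to compound 4 (1.88 log units; beyond the scatter). Among the groups that hold a carbonyl, what sits on the carbonyl carbon matters: anilino in place of 4-chlorophenyl gives a 20-fold lower number from compound 2 to compound 4 (1.29 log units; beyond the scatter), and anilino in place of methyl gives a 320-fold lower number from compound 1 to compound 4 (2.51 log units; beyond the scatter), so a carbonyl alone does not set the number, as compound 1 also shows by standing above the sulfonyl compound 3. Nothing shown here explains why this change moves the number so far.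

Going by these compounds, it remains open whether a 4-chloroanilino or a benzylamino on the same carbonyl carbon would keep a number near that of compound 4. On these data alone, whether the methyl on this nitrogen can give way to an ethyl or a hydrogen is also open.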